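The source may report more compounds than this note shows. Statements on the series, on what has been measured and on what is new or still open speak of the compounds shown alone.

Compound 1 `CCN(CC)CCCNc1nc(-c2ccc(NC(=O)Nc3ccccc3)cc2)nc2c(Cl)c(Cl)sc12` gives 850 nM in a functional assay on NCI-H460 cells (Homo sapiens) for cytotoxicity, read by MTT assay, with a stated time of 72 h; a higher number here means a weaker inhibitor, a lower number a stronger inhibitor. Going by the values given here, compound 2 `CCN(CC)CCCNc1nc(-c2ccc(NC(=O)Nc3ccc(Cl)cc3)cc2)nc2c(Cl)c(Cl)sc12` gives 270 nM in this assay, the lowest of the two numbers so far, with compound 1 as its only neighbour. Compound 3 `CCN(CC)CCCNc1nc(-c2ccc(NC(=O)Nc3ccc(Cl)cc3Cl)cc2)nc2c(Cl)c(Cl)sc12` differs from compound 2 by chloro in place of hydrogen on an aromatic carbon. Among the compounds with values here, the one measured step that bears on this, a 3.1-fold lower number from compound 1 to compound 2 (0.50 log units; beyond the scatter), was also a chloro in place of hydrogen on an aromatic carbon, and a further lowering of similar or smaller size is therefore expected. Compound 3 is estimated at 200 nM in this assay, between 80 nM and 600 nM. The expected step is a 1.4-fold lower number from compound 2 to compound 3 (0.13 log units; within the scatter).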

Compound 3, half-maximal inhibitory concentration: 1170 nM
Beside the measured number, compound 3's estimate is 5.9-fold (0.77 log units) below it; the measured number lies above the stated range.
By their numbers in this assay, from the lowest: compound 2; then compounds 1 and 3 (each within the scatter of the next).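

In this assay, chloro in place of hydrogen does not act the same at each place on this ring: ortho to a large group and meta to a chloro group it gives a 4.3-fold higher number from compound 2 to compound 3 (0.64 log units; beyond the scatter) and so runs opposite to a 3.1-fold lower number from compound 1 to compound 2 (0.50 log units; beyond the scatter) in direction. The 2,4-dichlorophenyl group and plain phenyl stand level, with a 1.4-fold higher number from compound 1 to compound 3 (0.14 log units; within the scatter) between them. No evidence is available that accounts for this reversal. The compounds shown leave open whether fluoro or methoxy at this same place would raise the number as chloro does.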